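Resorcinol lipid series: hydroxylated chain analogue, cytotoxicity outlook

The source may report more compounds than this note shows. Statements on the series, on what has been measured and on what is new or still open speak of the compounds shown alone.

Among the measured compounds shown here, compound 1 `CC/C=C\C/C=C\C/C=C\CCCCCCCc1cc(O)cc(O)c1` gives 104000 nM in an ADME assay on Vero cells (Homo sapiens) for cytotoxicity against Vero (Chlorocebus sabaeus), read by MTT assay; a higher number here means a weaker inhibitor, a lower number a stronger inhibitor; of the two numbers so far this is the lowest, but compound 2 `CCCCC/C=C\C/C=C\CCCCCCCc1cc(OC(C)=O)cc(OC(C)=O)c1` with 124000 nM sits within the scatter of it, so no order between the two can be read. Compound 3 `CC/C=C\C[C@@H](O)CC/C=C\CCCCCCCc1cc(O)cc(O)c1` differs from compound 1 by a group of 8 heavy atoms (7 carbon, 1 oxygen; no ring) in place of a group of 7 heavy atoms (7 carbon; no ring), on a saturated chain carbon bound to a double-bonded chain carbon. For the measured compounds named here, no step between measured compounds covers this kind of change. The step of a 1.2-fold higher number from compound 1 to compound 3 (0.06 log units; within the scatter) is expected to stay within the scatter, with no direction claimed. Compound 3 is estimated at 120000 nM in this assay, with a range from 55000 nM to 260000 nM.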

Compound 3, half-maximal inhibitory concentration: 30000 nM
Beside the measured number, compound 3's estimate is 4.0-fold (0.60 log units) above it; the measured number lies below the stated range.
By their numbers in this assay, from the lowest: compound 3; then compounds 1 and 2 (each within the scatter of the next).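

In this assay, the position on a saturated chain carbon bound to a double-bonded chain carbon responds to substitution: replacing hepta-1,4-dien-1-yl with the oxygen-bearing group gives a 3.5-fold lower number from compound 1 to compound 3 (0.54 log units; beyond the scatter) and separates compound 3 from the earlier pair. This single change adds an oxygen and a defined stereocentre and removes a double bond, so the step cannot be assigned to any one of these. No measured evidence explains the shift. On these data alone, the opposite stereoisomer remains open, as does whether an amine or a carboxylic acid at this carbon would move the number further.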